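The source may report more compounds than this note shows. Statements on the series, on what has been measured and on what is new or still open speak of the compounds shown alone.

Measured compounds:
compound 1 `Cc1nccc(N2CCc3nc(C4(C(=O)Nc5ccc(F)cc5)CCC4)ccc32)n1`: "not determined" (no result reported)
compound 2 `COC(=O)N1c2ccc(C3(NC(=O)c4ccc(F)cc4)CC3)cc2[C@H]2CC[C@H]21`: 4.1 nM
compound 3 `Cc1nccc(N2c3ccc(C4(NC(=O)c5ccc(F)cc5)CC4)cc3[C@H]3CC[C@H]32)n1`: "not determined" (no result reported)

In an assay on blood for inhibition of Indoleamine 2,3-dioxygenase 1 (Homo sapiens) (on this read-out lower numbers stand for stronger inhibition and higher numbers for weaker inhibition), compound 1 has no single number, and compound 3 has none either. Only compound 2 gives a figure, 4.1 nM in this assay. Compound 1 therefore stands nowhere on the numbers shown, and no step between measured compounds can be drawn from this set.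

Compound 4 `O=C(c1cccc(Cl)c1)N1CCc2nc(C3(C(=O)Nc4ccc(F)cc4)CCC3)ccc21` is the untested analogue of compound 1. The change: (3-chlorophenyl)carbonyl in place of 2-methylpyrimidin-4-yl on a nitrogen on an aromatic ring in a ring The (3-chlorophenyl)carbonyl enters on a nitrogen on an aromatic ring in a ring, where compound 1 carries 2-methylpyrimidin-4-yl. With no number for compound 1, neither the size nor the direction of this step in this assay can be stated; it may fall within the scatter or well beyond it. The sole anchor for the series is compound 2 at 4.1 nM in this assay, on a different core. Compound 4 is expected to read near 20 nM, estimated between 3 nM and 150 nM.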

Compound 4, half-maximal inhibitory concentration: 0.84 nM
The estimate for compound 4 lay 24-fold (1.38 log units) above the measured number, and the stated range ends above it.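

Among the compounds shown here, no step from compound 1 to compound 4 can be read in this assay: compound 1 has no single number, and compound 4 at 0.84 nM stands alone. Going by these compounds, whether (3-chlorophenyl)carbonyl in place of 2-methylpyrimidin-4-yl strengthens or weakens inhibition on the shared core stays open. No evidence bearing on this result is available.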